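Pentafluoroethyl for bicyclopentyl on a benzamide core

This account rests on a few compounds, and the source may have more. Where it says the series, first, only, none or still open, it means among the compounds named here.

Measured compounds:
compound 1 `CS(=O)(=O)Nc1ccc(CNC(=O)c2ccc(C34CC(C3)C4)cc2)c(Cl)c1` 1.35 h
compound 2 `CS(=O)(=O)Nc1ccc(CNC(=O)c2ccc(N3CCCCC3)cc2)c(Cl)c1` 1.12 h
compound 3 `COC(C)(C)c1ccc(C(=O)NCc2ccc(NS(C)(=O)=O)cc2Cl)cc1` 0.917 h

In an ADME assay on microsomes from liver (Rattus norvegicus, strain Sprague-Dawley) for metabolic stability, read by HPLC, using NADPH, with stated times of 5 min and 60 min, tested at 10 uM (on this read-out higher numbers stand for a longer-lived compound and lower numbers for a shorter-lived compound), compound 1 gives 1.35 h, the highest of the three numbers, but its separation from the others is small: a 1.2-fold lower number from compound 1 to compound 2 (0.08 log units; within the scatter) and a 1.5-fold lower number from compound 1 to compound 3 (0.17 log units; within the scatter). Between the other two, a 1.2-fold lower number from compound 2 to compound 3 (0.09 log units; within the scatter). The three compounds therefore sit in one band, with no ordering that the measurement can support.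

Compound 4 `CS(=O)(=O)Nc1ccc(CNC(=O)c2ccc(C(F)(F)C(F)(F)F)cc2)c(Cl)c1` is not yet measured in this assay. It differs from compound 1 in one place: a group of 7 heavy atoms (2 carbon, 5 fluorine; no ring) in place of a group of 5 heavy atoms (5 carbon; 2 four-membered non-aromatic rings of carbon only), on an aromatic carbon. Going by the values given here, no measured step touches a pentafluoroethyl group, so the bearing of the earlier steps is indirect. What they do show is that exchanging the group on this aromatic carbon for a piperidin-1-yl or a 1-methoxy-1-methylethyl group moved the half-life only within the scatter. On that basis the step of a 1.0-fold lower number from compound 1 to compound 4 (0.02 log units; within the scatter) is expected to stay within the scatter as well, with no clear direction. Compound 4 is estimated at 1.3 h, in a range from 0.7 h to 2.5 h.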

Compound 4, half-life: 1.6 h
Compound 4: the middle estimate sits 1.2-fold (0.09 log units) below what was measured, and the stated range covers the measured number.
By their numbers in this assay, from the lowest: compounds 3, 2, 1 and 4 (each within the scatter of the next).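

In this assay the 1,1,2,2,2-pentafluoroethyl group falls in the same band as the three earlier groups: there is a 1.2-fold higher number from compound 1 to compound 4 (0.07 log units; within the scatter), alongside a 1.4-fold higher number from compound 2 to compound 4 (0.15 log units; within the scatter) and a 1.7-fold higher number from compound 3 to compound 4 (0.24 log units; within the scatter). The earlier compounds shown here did not show that a group built only of carbon and fluorine, with no ring, also leaves the half-life within the scatter at this position on the aromatic carbon, para to a large group; all four groups now stand within the scatter of one another, so the set gives no ordering among them. Nothing at hand bears on what lies behind these numbers.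

The compounds shown leave open whether any group at this position can move the half-life beyond the scatter, for instance a carboxylic acid, a primary amine or a longer chain such as nonafluorobutyl. They also leave open whether the same insensitivity to the group at this position would hold if the chlorine on the shared core were replaced by hydrogen.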